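The source may hold more compounds than are shown below. What is called first, only, known or untested is meant among the compounds shown, and "the series" means these compounds.

In an ADME assay on microsomes from liver (Mus musculus, strain CD-1) for metabolic stability, read by LC-MS, with a stated time of 60 min, tested at 20 uM (a lower number here means that the compound disappears faster, a higher number that the compound lasts longer), compound 1 `CC(Sc1nc2c(cnn2C)c(=O)n1-c1ccccc1)c1ccccn1` gives 0.833 h, the higher of the two numbers shown, though its gap to compound 2 lies within the scatter and the two are not distinguished. Compound 2 `CC(Sc1nc2nn(C3COC3)cc2c(=O)n1-c1ccccc1)c1ccccc1` gives 0.783 h. Compound 3 `CC(Sc1nc2nn(C3(C)COC3)cc2c(=O)n1-c1ccccc1)c1ccccc1` reaches only a limit of the assay, > 1 h, so that the limit of > 1 h in this assay, at which 1 of the 3 values shown sits, applies. Within the data shown here, the single one-place step, an at least 1.2-fold higher number from compound 2 to compound 3 (0.10 log units; that floor lies within the scatter), has a floor within the scatter. Compound 4 `CC(Sc1nc2c(cnn2C)c(=O)n1-c1ccccc1)c1cccc(F)c1` differs from compound 1 by 3-fluorophenyl in place of pyridin-2-yl on a saturated chain carbon bound to a saturated chain carbon and a sulfur. Among the measured compounds shown here, no measured step bears on this change; compounds 1 and 2, which differ at this carbon and elsewhere, sit within the scatter of each other. The expected step is therefore a 1.0-fold higher number from compound 1 to compound 4 (0.01 log units; within the scatter), nothing beyond the scatter. Compound 4 is estimated at 0.85 h, within 0.45 h to 1 h in this assay.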

Compound 4, half-life: 0.133 h
For compound 4 the middle estimate is 6.4-fold (0.81 log units) above the measured one; the whole stated range lies above it.
By their numbers in this assay, from the lowest: compound 4; then compounds 2 and 1 (each within the scatter of the next). At a limit, above all of these: compound 3.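

In this assay, the group on the saturated chain carbon bound to a saturated chain carbon and a sulfur matters: 3-fluorophenyl in place of pyridin-2-yl gives a 6.3-fold lower number from compound 1 to compound 4 (0.80 log units; beyond the scatter). This is the only one-place step shown that lies beyond the scatter, so this position, unlike the earlier comparisons, shows a clear dependence on the group it carries. Nothing measured here accounts for the size of the step.

This single swap does not separate the loss of the ring nitrogen from the gain of fluorine. Going by these compounds, whether pyridin-3-yl or 3-chlorophenyl at this carbon would track compound 1 or compound 4 remains open.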